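Changing the carbonyl group: from compound 3 to compound 4

The source may report more compounds than this note shows. Statements on the series, on what has been measured and on what is new or still open speak of the compounds shown alone.

Compound 1 `COc1cc(OC)cc(C(=O)NCCNC(=O)[C@H](CC(=O)NC(C)(C)C)NS(=O)(=O)c2ccc(C)cc2)c1` gives > 11000 nM as a limit
Compound 2 `Cc1ccc(S(=O)(=O)N[C@@H](CC(=O)NC(C)(C)C)C(=O)NCCNC(=O)c2cccc(F)c2)cc1` gives > 11000 nM as a limit
Compound 3 `Cc1ccc(S(=O)(=O)N[C@@H](CC(=O)NC(C)(C)C)C(=O)NCCNC(=O)c2cc(C)ccc2F)cc1` gives > 11000 nM as a limit

All three were tested in an ADME assay on HepG2 cells (Homo sapiens) for cytotoxicity (on this read-out higher numbers stand for an effect only at larger amounts of compound and lower numbers for an effect already at smaller amounts), and give limits, not numbers. Compound 3 thus stands at the limit of > 11000 nM in this assay, at which 3 of the 3 values shown sit, with nothing finer to read. Compound 4 `Cc1ccc(S(=O)(=O)N[C@@H](CC(=O)NC(C)(C)C)C(=O)NCCNC(=O)c2ccccn2)cc1` carries pyridin-2-yl in place of 2-fluoro-5-methylphenyl on a carbonyl carbon. The measured changes at this place are a step that the two limits leave unreadable from compound 1 to compound 2 and a step that the two limits leave unreadable from compound 1 to compound 3 and a step that the two limits leave unreadable from compound 2 to compound 3 as well. Their sizes cannot be read, yet every compound stays at the limit. No step beyond the scatter is therefore expected in this assay in either direction. The estimated move is a step that the limit leaves unreadable from compound 3 to compound 4 on this reasoning. For compound 4 the expected value is 15000 nM within an estimated range from 11000 nM to 40000 nM and most likely only a limit will be reported.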

Compound 4, half-maximal effective concentration: > 11000 nM
Compound 4 was reported as a limit; the forecaster's own chance of this, stated with the estimate: 90%; the middle value lies beyond the limit too.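

Compound 4 is reported only as a limit, like compound 1, compound 2 and compound 3, so no step among them can be read in this assay: the limit of > 11000 nM in this assay, at which 4 of the 4 values shown sit.

The compounds shown leave open where each true value lies beyond that limit, and whether they differ at all.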